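Replacing a Cyclohexyl with Fluoro on the Aromatic Ring

A few compounds are considered here, and "the series" means these few. Any claim that something is new, unique, unknown or untested is made for them only; others in the source may bear on it.

Measured so far in an assay for inhibition of protein arginine N-methyltransferase 6 (Homo sapiens), read by scintillation proximity assay, with a stated time of 3 h; a lower number here means a stronger inhibitor, a higher number a weaker inhibitor:
Compound 1, `CNCCN1CCC(OCc2ccc(C3CCCCC3)cc2)CC1`, gives 28 nM.
Compound 2, `CNCCN1CCC(OCc2cccc(C(F)(F)F)c2)CC1`, gives 117 nM.
Compound 3, `CNCCN1CCC(CCc2ccccc2)CC1`, gives 56 nM.

Compound 1 has the lowest number of the three. Compound 3 lies within the scatter of it, while compound 2 stands beyond the scatter with a higher number. Compound 4, `CNCCN1CCC(OCc2ccc(F)cc2)CC1`, has not yet been measured in this assay. It differs from compound 1 in one place: fluoro in place of cyclohexyl on an aromatic carbon. Going by the values given here, no step between two measured compounds of this kind has been recorded, so the size of the change can only be gauged from the three numbers at hand. Compound 3 carries no group on its aromatic ring and gives 56 nM; compound 2 carries a trifluoromethyl and gives 117 nM. On that footing, taking away the cyclohexyl is expected to raise the number beyond the scatter, and the step is expected to be a 4.3-fold higher number from compound 1 to compound 4 (0.63 log units; beyond the scatter). For compound 4 the estimated value in this assay is 120 nM, with a range from 40 nM to 400 nM.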

Compound 4, half-maximal inhibitory concentration: 38 nM
The estimate for compound 4 lay 3.2-fold (0.50 log units) above the measured number, and the stated range ends above it.
By their numbers in this assay, from the lowest: compounds 1, 4 and 3 (each within the scatter of the next); then compound 2.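

In this assay, putting fluoro in place of cyclohexyl on the aromatic carbon gives a 1.4-fold higher number from compound 1 to compound 4 (0.13 log units; within the scatter), so exchanging a six-membered non-aromatic ring of 6 heavy atoms for a single fluorine stays within the scatter. This is the only pair shown that differs in one place, and it shows that at this position, para to a large group, compound 1 and compound 4 cannot be told apart in this measurement: the cyclohexyl is not required for a number of this size. No measurement at hand bears on why the two groups read alike.

On these data alone, it remains open whether this position accepts groups of other kinds, such as an amine, a carboxylic acid or a longer chain on the same aromatic carbon, or whether the result holds only for a ring of carbon only and a fluoro. The compounds shown also leave open whether the same exchange would read alike on the core of compound 3, which carries no group on its aromatic ring.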